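Methyl at the acid-bearing carbon: compound 2 to compound 4

The source may report more compounds than this note shows. Statements on the series, on what has been measured and on what is new or still open speak of the compounds shown alone.

compound 1 `CC(C(=O)O)c1nn(Cc2cn3cc(OCC4CC4)c(Cl)cc3n2)c2ccccc2c1=O`: 15 nM
compound 2 `O=C(O)Cc1nn(Cc2cn3cc(OCC4CC4)c(Cl)cc3n2)c2ccccc2c1=O`: 60 nM
compound 3 `CC(C(=O)O)c1nn(Cc2cn3cc(OCC4CC4)c(C(F)(F)F)cc3n2)c2ccccc2c1=O`: 56 nM

In a functional assay on HFL1 cells for antagonist activity at sphingosine 1-phosphate receptor 2 (Homo sapiens), read by ELISA, with a stated time of 24 h, in the presence of a further agent that is not named here (on this read-out higher numbers stand for weaker inhibition and lower numbers for stronger inhibition), compound 2 sits at the high end of the three numbers; compound 3 lies within the scatter of it, and only compound 1 is clearly lower, the gap being a 4.0-fold higher number from compound 1 to compound 2 (0.60 log units; beyond the scatter) read in reverse. Compound 4 `C[C@H](C(=O)O)c1nn(Cc2cn3cc(OCC4CC4)c(Cl)cc3n2)c2ccccc2c1=O` differs from compound 2 by methyl in place of hydrogen on a saturated chain carbon bound to an aromatic carbon and a carbonyl carbon. Among the measured compounds shown here, the one step that bears on this is that same change in the opposite direction, a modest shift; a 3.7-fold higher number from compound 1 to compound 3 (0.57 log units; beyond the scatter) concerns another place on the core and does not bear here. A modest step toward a lower number is therefore expected, a 5.0-fold lower number from compound 2 to compound 4 (0.70 log units; beyond the scatter). For compound 4 in this assay the estimate is 12 nM, with a range of 4 nM to 40 nM.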

Compound 4, half-maximal inhibitory concentration in the sphingosine 1-phosphate receptor 2 assay: 19 nM
Compound 4: the middle estimate sits 1.6-fold (0.20 log units) below what was measured; measured number inside the range.
By their numbers in the sphingosine 1-phosphate receptor 2 assay, from the lowest: compounds 1 and 4 (each within the scatter of the next); then compounds 3 and 2 (each within the scatter of the next).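

In the sphingosine 1-phosphate receptor 2 assay, compound 2 gives 60 nM and compound 4 gives 19 nM, and the methyl on the saturated chain carbon bound to an aromatic carbon and a carbonyl carbon keeps its gain when drawn as the S centre: a 3.2-fold lower number from compound 2 to compound 4 (0.50 log units; beyond the scatter). In the sphingosine 1-phosphate receptor 2 assay, the S form cannot be told apart from the form drawn without a configuration, a 1.3-fold higher number from compound 1 to compound 4 (0.10 log units; within the scatter), and the only difference is this: the fact that one of compounds 1 and 4 is drawn with a defined configuration and the other without, at the place where they differ In a physicochemical assay for solubility, measured as thermodynamic solubility, at pH 7.4 (on this read-out higher numbers stand for higher solubility and lower numbers for lower solubility), compound 2 gives 919 ug/mL and compound 4 gives 892 ug/mL, and the same methyl step gives a 1.0-fold lower number from compound 2 to compound 4 (0.01 log units; within the scatter).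

The compounds shown leave open how the R form compares in the sphingosine 1-phosphate receptor 2 assay. They also leave open whether ethyl in place of methyl at this carbon holds up in the sphingosine 1-phosphate receptor 2 assay.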